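Moving a Pyridine Nitrogen on Two Different Cores

The source may report more compounds than this note shows. Statements on the series, on what has been measured and on what is new or still open speak of the compounds shown alone.

Four compounds are compared in a functional assay on HEK293 cells for antagonist activity at metabotropic glutamate receptor 5 (Homo sapiens), read by FLIPR and calcium flux; on this read-out lower numbers stand for stronger inhibition and higher numbers for weaker inhibition. Compound 1, `O=C(N[C@H]1CCC[C@H](NC(=O)c2cccc(Cl)c2)C1)c1cccnc1`, carries a (pyridin-3-yl)carbonyl amide on a shared core; in this assay compound 1 gives 612 nM. Compound 2, `O=C(N[C@H]1CCC[C@H](NC(=O)c2cccc(Cl)c2)C1)c1ccncc1`, differs only by pyridin-4-yl in place of pyridin-3-yl on a carbonyl carbon. In this assay compound 2 gives 300 nM, so the change gives a 2.0-fold lower number from compound 1 to compound 2 (0.31 log units; beyond the scatter).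

Compound 3, `O=C(NC1CCCC2(CN=C(c3cccc(Cl)c3)O2)C1)c1cccnc1`, has a different core, and how its core differs from that of compound 1 is not broken down here. In this assay compound 3 reaches only a limit, > 10000 nM, which is a limit of the assay and not a measured number. This is the limit of > 10000 nM in this assay, at which 1 of the 3 values shown sits.

Compound 4, `O=C(NC1CCCC2(CN=C(c3cccc(Cl)c3)O2)C1)c1ccncc1`, is not yet measured. It differs from compound 3 by pyridin-4-yl in place of pyridin-3-yl on a carbonyl carbon, which is the same kind of change that was made from compound 1 to compound 2. Going by the values given here, the only measured example of this change is a modest one, and compound 3 sits at the limit of the assay, so a change of that size would be expected to leave compound 4 near or beyond that limit as well. The expected step from compound 3 to compound 4 in this assay is a step that the limit leaves unreadable from compound 3 to compound 4. Compound 4 is therefore estimated to give about 20000 nM in this assay, with a range from 5000 nM to 80000 nM, and most likely only a limit will be reported.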

Compound 4, half-maximal inhibitory concentration: > 10000 nM
Compound 4 ended at the assay's limit; the forecaster's own chance of this, stated with the estimate: 80%; the middle value is on the limit's open side.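

In this assay compound 4 gives > 10000 nM as a limit of the assay and not a measured number. Going by these compounds alone, no step between compound 3 and compound 4 can be read, as both stop at the same limit: the limit of > 10000 nM in this assay, at which 2 of the 4 values shown sit. Going by these compounds, what stays open is whether pyridin-4-yl in place of pyridin-3-yl changes inhibition at all on the core of compound 3, as it does on the core of compound 1.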